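This account rests on a few compounds, and the source may have more. Where it says the series, first, only, none or still open, it means among the compounds named here.

In an assay for inhibition of Rho-associated protein kinase 1 (Homo sapiens), read by TR-FRET, with stated times of 5 min and 2 h (on this read-out higher numbers stand for weaker inhibition and lower numbers for stronger inhibition), compound 1 `Cc1n[nH]cc1-c1cc2c(s1)C(=O)N[C@]1(CC[C@@](O)(c3ccc(F)cc3)CC1)N2` gives 130 nM. Among the three compounds measured so far, compound 1 stands second highest. Compound 2 `O=C1NC2(CCCCCC2)Nc2cc(-c3ccncc3)sc21` gives 37 nM, a lower number, while compound 3 `Cc1n[nH]cc1-c1cc2c(s1)C(=O)N[C@]1(CC[C@](O)(c3ccc(F)cc3)CC1)N2` gives 820 nM, the highest of the three. Compound 3 is the mirror image of compound 1, and the step of a 6.3-fold higher number from compound 1 to compound 3 (0.80 log units; beyond the scatter) shows that a change in configuration alone moves the number beyond the scatter; this shift can be tied to stereochemistry because of the fact that compounds 1 and 3 differ only in the configuration as drawn.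

Compound 4 `Cc1n[nH]cc1-c1cc2c(s1)C(=O)N[C@]1(CC[C@@](O)(C3CCCCC3)CC1)N2` has not yet been measured. It differs from compound 1 by cyclohexyl in place of 4-fluorophenyl on a saturated ring carbon, with the configuration of compound 1 kept. Within the data shown here, none of the measured steps bears on a change of this kind. Among the measured compounds shown here, the only measured step concerns configuration, not the identity of the group on that carbon, so it gives no guide to the size or direction of the present change. With nothing to push the expectation either way, compound 4 is expected to give 200 nM, within a range from 60 nM to 700 nM. This estimate means a step of a 1.5-fold higher number from compound 1 to compound 4 (0.19 log units; within the scatter), expected to stay within the scatter, though the range is wide.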

Compound 4, half-maximal inhibitory concentration: 350 nM
Compound 4: middle estimate off by 1.8-fold (0.24 log units), on the low side; measured number inside the range.
By their numbers in this assay, from the lowest: compound 2; then compound 1; then compound 4; then compound 3.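

In this assay, the swap of 4-fluorophenyl for cyclohexyl on this saturated ring carbon, with the configuration of compound 1 kept, gives a 2.7-fold higher number from compound 1 to compound 4 (0.43 log units; beyond the scatter), so inhibition is weaker with the non-aromatic ring. Among these compounds, until now, the only measured change at this part of the molecule was one of configuration; this step adds that the identity of the ring on this carbon also moves the number beyond the scatter, though only modestly, and that compound 4 with its cyclohexyl group still gives 350 nM. Nothing measured here explains why the cyclohexyl compound gives the higher number.

The change removes both the aromatic ring and the fluorine at once, so the compounds shown cannot say which of the two matters; a plain phenyl group, without fluorine, on the same carbon would separate them. Also open, going by these compounds, are how a group of another kind, such as an amine or a carboxylic acid, would behave at this position, and whether inverting the configuration would shift the number for the cyclohexyl compound as it does for the 4-fluorophenyl pair.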